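Chain-end ring change from compound 3 to compound 4

The source may hold more compounds than are shown below. What is called first, only, known or untested is meant among the compounds shown, and "the series" means these compounds.

In a functional assay on SMMC-7721 cells (Homo sapiens) for antiproliferative activity, read by MTT assay, with a stated time of 48 h (on this read-out higher numbers stand for weaker inhibition and lower numbers for stronger inhibition), the measured compounds give:
compound 1 `Cn1cc(C2=C(c3nn(CCCn4cccc4)c4ncccc34)C(=O)N(c3ccccc3)C2=O)c2ccccc21`: > 100000 nM, a limit of the assay
compound 2 `CN(C)CCCn1nc(C2=C(c3cn(C)c4ccccc34)C(=O)N(c3ccccc3)C2=O)c2cccnc21`: 31200 nM
compound 3 `Cn1cc(C2=C(c3nn(CCCCn4ccnc4)c4ncccc34)C(=O)N(c3ccccc3)C2=O)c2ccccc21`: 1760 nM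

Compound 3 gives the lowest number shown, and its nearest neighbour is compound 2, with the step of an 18-fold lower number from compound 2 to compound 3 (1.25 log units; beyond the scatter). Compound 1 reaches only the limit (the limit of > 100000 nM in this assay, at which 1 of the 3 values shown sits). Compound 4 `Cn1cc(C2=C(c3nn(CCCn4cncn4)c4ncccc34)C(=O)N(c3ccccc3)C2=O)c2ccccc21` differs from compound 3 by 1H-1,2,4-triazol-1-yl in place of (1H-imidazol-1-yl)methyl on a saturated chain carbon, three bonds along the chain from an aromatic nitrogen. Going by the values given here, the steps of an at least 56-fold lower number from compound 1 to compound 3 (1.75 log units; beyond the scatter) and an 18-fold lower number from compound 2 to compound 3 (1.25 log units; beyond the scatter) show that the group at this place moves this assay strongly, but no measured step tests this particular change. A modest loss is expected, a 2.3-fold higher number from compound 3 to compound 4 (0.36 log units; beyond the scatter). Compound 4 is therefore estimated at 4000 nM, between 1200 nM and 15000 nM.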

Compound 4, half-maximal inhibitory concentration: > 100000 nM
Compound 4: only a limit was reported (the forecaster's own chance of this, stated with the estimate: 5%); at least 25-fold (1.39 log units) between middle value and limit.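

In this assay, the change at this place is far from neutral: an at least 56-fold higher number from compound 3 to compound 4 (1.75 log units; beyond the scatter) shows that the activity of compound 3 does not survive this change, and an at least 3.2-fold higher number from compound 2 to compound 4 (0.50 log units; beyond the scatter) places the 3-(1H-1,2,4-triazol-1-yl)propyl group behind even dimethylamino on the same chain. The value of compound 4 is a limit of the assay, as is that of compound 1: the limit of > 100000 nM in this assay, at which 2 of the 4 values shown sit. The step between these two compounds cannot be read.

Ring and chain length change together here, so the compounds shown do not tell which of them carries the loss. A 3-(1H-imidazol-1-yl)propyl or a 4-(1H-1,2,4-triazol-1-yl)butyl group would separate the two.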